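The compounds below may be only part of what the source reports. "The series", "measured", "known", "first", "only" and "open" are said of these compounds alone.

Compound 1, `COCCn1cc(C(=O)C(=O)Nc2ccc(OC)nc2)c2cc(Cl)ccc21`, gives in a functional assay on FaDu cells (Homo sapiens) for cytotoxicity, read by MTT assay, with a stated time of 72 h (on this read-out higher numbers stand for lower toxicity in this test and lower numbers for higher toxicity in this test), a value of > 10000 nM, which is a limit of the assay and not a number.
Compound 2, `COc1ccc(NC(=O)C(=O)c2cn(C(C)C)c3ccc(Cl)cc23)cn1`, gives in this assay a value of > 10000 nM, again a limit rather than a number.
Compound 3, `COCCn1cc(C(=O)C(=O)Nc2ccnc(OC)c2)c2ccccc21`, gives in this assay a value of 235 nM.

Compound 4, `COc1cc(NC(=O)C(=O)c2cn(C(C)C)c3ccccc23)ccn1`, has not yet been measured. It is derived from compound 3 by one change: isopropyl in place of 2-methoxyethyl on an aromatic nitrogen. The same change, at the same place, carries compound 1 into compound 2: isopropyl in place of 2-methoxyethyl on an aromatic nitrogen. That measured step, a step that the two limits leave unreadable from compound 1 to compound 2, cannot be sized because both of its values sit at the limit of > 10000 nM in this assay, at which 2 of the 3 values shown sit. How the core of compound 1 differs from the core of compound 3 is not broken down here; compound 3 is the only one of the three with a number rather than a limit.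

Within the data shown here, for the step from compound 3 to compound 4, the account expects a small change, a 1.5-fold higher number from compound 3 to compound 4 (0.17 log units; within the scatter), because the one measured instance of this change, a step that the two limits leave unreadable from compound 1 to compound 2, offers no readable size and so gives no ground for a large shift. Compound 4 is therefore estimated to give 350 nM in this assay, with a likely range from 100 nM to 2500 nM.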

Compound 4, concentration lethal to 50% of the cells: 1750 nM
Compound 4: middle estimate off by 5.0-fold (0.70 log units), on the low side; low and high end bracket the measured number.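

In this assay, isopropyl in place of 2-methoxyethyl on an aromatic nitrogen gives a 7.4-fold higher number from compound 3 to compound 4 (0.87 log units; beyond the scatter), so on the core of compound 3 the change raises the number, which on this read-out stands for lower toxicity in this test. The same change on the core of compound 1 cannot be read, since compound 1 and compound 2 both sit at a limit of the assay and not at a number: the limit of > 10000 nM in this assay, at which 2 of the 4 values shown sit. The new step therefore shows what the change does on one core only, and it does not show that its size, or even its direction, carries over from one core to another.

The compounds shown leave open whether another group on that aromatic nitrogen, such as a longer chain ending in an amine or a carboxylic acid, would move the number further in this assay. They also leave open how large the change would be on any further core that gives a number rather than a limit.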